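Plasma stability: changing the carboxyphenyl end of compound 2

This account rests on a few compounds, and the source may have more. Where it says the series, first, only, none or still open, it means among the compounds named here.

In an ADME assay on a cell-free system (plasma, Rattus norvegicus) for metabolic stability, read by LC-MS, with a stated time of 60 min, tested at 100 uM (a higher number here means that more of the compound is left, a lower number that less of the compound is left), compound 1 `Cc1c(OCCCCOc2ccc(C(=O)O)cc2)ccc(C(=O)CC(C)C)c1O` gives 95% and compound 2 `Cc1c(OCCCCOc2ccc(C(=O)O)cc2Cl)ccc(C(=O)CC(C)C)c1O` gives 123%. Compound 2 therefore holds the higher of the two numbers, and the gap between them lies beyond the scatter.

Compound 3 `Cc1ccc(C(=O)O)cc1OCCCCOc1ccc(C(=O)CC(C)C)c(O)c1C` has not yet been measured. Relative to compound 2, it carries 5-carboxy-2-methylphenyl in place of 4-carboxy-2-chlorophenyl on an oxygen on a saturated carbon.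

Going by the values given here, only one measured step bears on this change: a number 28 percentage points higher from compound 1 to compound 2 (beyond the scatter), a modest step for chloro in place of hydrogen on an aromatic carbon. Compound 3 has no chloro, which points to a fall back towards the level of compound 1 at 95%. Among the compounds with values here, no measured step covers the methyl group or the 5-carboxy arrangement, so this guidance is only partial. A modest fall in this assay is expected, of about the same size as the measured step but in the opposite direction. The expected change is a number 21 percentage points lower from compound 2 to compound 3 (beyond the scatter). For compound 3 the estimated value is 102%, with an expected range of 82% to 122%.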

Compound 3, percent of the compound remaining: 96%
Estimate against measurement, compound 3: 6 percentage points above; the range from low to high includes it.
By their numbers in this assay, from the lowest: compounds 1 and 3 (each within the scatter of the next); then compound 2.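

In this assay the exchange of 4-carboxy-2-chlorophenyl for 5-carboxy-2-methylphenyl on an oxygen on a saturated carbon gives a number 27 percentage points lower from compound 2 to compound 3 (beyond the scatter) and so gives up the lead held by compound 2. Set against the 4-carboxyphenyl group, the same 5-carboxy-2-methylphenyl group gives a number 1 percentage points higher from compound 1 to compound 3 (within the scatter) and so leaves compound 1 and compound 3 indistinguishable here, with compound 2, the only chloro compound of the three, alone standing apart. This position therefore tolerates the combined methyl and carboxy rearrangement with no readable difference from the unsubstituted 4-carboxyphenyl end, though nothing available accounts for the separate reading of compound 2.

As far as these compounds go, the methyl group and the 5-carboxy arrangement enter together in this one exchange, so their separate contributions remain open, as does whether a chloro on the 5-carboxyphenyl end would give a number like that of compound 2. From the compounds shown here alone, it is also open whether the higher reading is particular to chloro or would recur with fluoro, bromo or methoxy on the 4-carboxyphenyl end.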